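Second chloro on the aryl ring: expected effect on growth inhibition

A few compounds are considered here, and "the series" means these few. Any claim that something is new, unique, unknown or untested is made for them only; others in the source may bear on it.

Compound 2 `O=C1NC(=S)/C(=C/c2ccccc2Cl)S1` has the lowest of the two numbers seen so far: in a functional assay on HEp-2 cells (Homo sapiens) for cytotoxicity, read by MTT assay, with a stated time of 72 h, tested at 5 ug/mL (on this read-out higher numbers stand for more inhibition of growth at the one concentration tested and lower numbers for less inhibition of growth), compound 2 gives 5.97%, while compound 1 `O=C1NC(=S)/C(=C/c2ccccc2Br)S1` gives 16.2%. Within the data shown here, the one measured step, a number 10.2 percentage points lower from compound 1 to compound 2 (beyond the scatter), concerns a halogen exchange and bears only loosely on compound 3 `O=C1NC(=S)/C(=C/c2c(Cl)cccc2Cl)S1`, where the change is chloro in place of hydrogen on an aromatic carbon. Among the measured compounds shown here, no step adds a halogen to the ring. Compound 3 is therefore expected to show a small step, a number 4 percentage points higher from compound 2 to compound 3 (within the scatter), not clearly beyond the scatter, with an estimated 10% and a range from 0% to 25%.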

Compound 3, percent growth inhibition at one concentration: -2.39%
Compound 3: middle estimate off by 12.4 percentage points, on the high side; the measured number lies below the stated range.
By their numbers in this assay, from the lowest: compounds 3 and 2 (each within the scatter of the next); then compound 1.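

Chloro in place of hydrogen on this aromatic carbon, ortho to a group of 8 heavy atoms and meta to a chloro group, is the first step here that adds a halogen to the ring, and in this assay it reads as a number 8.4 percentage points lower from compound 2 to compound 3 (within the scatter). This second chloro therefore brings no gain in growth inhibition over the single chloro at the one concentration tested. Nothing at hand accounts for this result. The compounds shown leave open whether an amine or a carboxylic acid on this same carbon would read any differently from chloro.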